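Swapping a thiophene for a benzene ring in a pyridine series

The compounds below may be only part of what the source reports. "The series", "measured", "known", "first", "only" and "open" are said of these compounds alone.

Compound 1 `Oc1ccc(-c2cc(-c3ccc(Cl)cc3)nc(-c3cccs3)c2)cc1` gives 7660 nM in a functional assay on DU-145 cells (Homo sapiens) for cytotoxicity, read by CCK-8 assay and cell counting, with a stated time of 2 days; on this read-out lower numbers stand for stronger inhibition and higher numbers for weaker inhibition. For the measured compounds named here, its relative compound 2 `Oc1ccc(-c2cc(-c3ccc(Cl)cc3)nc(-c3ccsc3)c2)cc1` gives 6940 nM in this assay, so the two numbers sit within the usual scatter of each other; the only measured step, a 1.1-fold lower number from compound 1 to compound 2 (0.04 log units; within the scatter), confirms this. Compound 3 `Oc1ccc(-c2cc(-c3ccccc3)nc(-c3ccc(Cl)cc3)c2)cc1` differs from compound 2 by a single change: phenyl in place of thiophen-3-yl on an aromatic carbon. Going by the values given here, no measured step mirrors this exchange; the one known ring swap was small. For compound 3 the change is therefore expected to give a 1.2-fold lower number from compound 2 to compound 3 (0.06 log units; within the scatter), with an estimate of 6000 nM in this assay, between 2500 nM and 15000 nM.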

Compound 3, half-maximal inhibitory concentration: 7270 nM
Estimate against measurement, compound 3: 1.2-fold (0.08 log units) below; low and high end bracket the measured number.
By their numbers in this assay, from the lowest: compounds 2, 3 and 1 (each within the scatter of the next).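

In this assay phenyl in place of thiophen-3-yl gives a 1.0-fold higher number from compound 2 to compound 3 (0.02 log units; within the scatter) and phenyl in place of thiophen-2-yl gives a 1.1-fold lower number from compound 1 to compound 3 (0.02 log units; within the scatter) at this same place next to the ring nitrogen. A six-membered aromatic ring of carbon only, with no sulfur, thus stays within the scatter of both thiophenes, something the two thiophenes alone could not show. As far as these compounds go, whether a group that is not an aromatic ring, such as an amine or a carboxylic acid, would move the number at this place remains open. Nothing available explains why these three compounds read alike.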